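Swapping a Sulfonyl Substituent in a Macrocyclic Series

This account rests on a few compounds, and the source may have more. Where it says the series, first, only, none or still open, it means among the compounds named here.

Three macrocycles have been tested for their effect on human cells. In an ADME assay on cells (Homo sapiens) for activation (on this read-out higher numbers stand for lower toxicity in this test and lower numbers for higher toxicity in this test), compound 1 `COc1ccc2c(OCC[C@@H]3NC(=O)N(C)CCCCC/C=C\[C@@H]4C[C@@]4(C(=O)NS(=O)(=O)C4CC4)NC3=O)cc(-c3ccccc3)nc2c1` gives 53000 nM, compound 2 `CCn1cc(-c2cc(OCC[C@@H]3NC(=O)N(C)CCCC/C=C\[C@@H]4C[C@@]4(C(=O)NS(=O)(=O)C4(C)CC4)NC3=O)c3ccc(OC)c(C)c3n2)cn1` gives 36700 nM, and compound 3 `COc1ccc2c(OCC[C@@H]3NC(=O)N(C)CCCC/C=C\[C@@H]4C[C@@]4(C(=O)NS(=O)(=O)N4CCC[C@H]4C#N)NC3=O)cc(-c3nc(C(C)C)cs3)nc2c1Cl` gives 28300 nM. Compound 3 carries the lowest of the three numbers, yet both other compounds sit within the usual scatter of it, so the three read as much the same on this assay.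

Compound 4 `COc1ccc2c(OCC[C@@H]3NC(=O)N(C)CCCC/C=C\[C@@H]4C[C@@]4(C(=O)NS(=O)(=O)N(C)C)NC3=O)cc(-c3nc(C(C)C)cs3)nc2c1Cl` is the next compound and has not been measured. It differs from compound 3 in one place: dimethylamino in place of 2-cyanopyrrolidin-1-yl on a sulfonyl sulfur. The smaller group thus replaces the larger ring-bearing one on the sulfonyl sulfur.

Among the measured compounds shown here, no measured pair in this set shows what such a swap does on this assay. Since all three measured compounds fall within the scatter of one another despite differing in several places, the step from compound 3 to compound 4 is expected to be small, a 1.2-fold higher number from compound 3 to compound 4 (0.09 log units; within the scatter), with no clear direction beyond the scatter. Compound 4 is therefore estimated at 35000 nM, within a range of 17000 nM to 70000 nM.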

Compound 4, half-maximal cytotoxic concentration: 47800 nM
Compound 4: the middle estimate sits 1.4-fold (0.14 log units) below what was measured; the range from low to high includes it.
By their numbers in this assay, from the lowest: compounds 3, 2, 4 and 1 (each within the scatter of the next).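

Among the compounds shown here, this is the first comparison in the set between two compounds that differ in only one place. In this assay, dimethylamino in place of 2-cyanopyrrolidin-1-yl on a sulfonyl sulfur gives a 1.7-fold higher number from compound 3 to compound 4 (0.23 log units; within the scatter). At this position, then, the ring, its nitrile and its defined stereocentre can all go, and the group can drop from 7 heavy atoms to 3, without a difference that this read-out can separate from the scatter. No measurement shown here accounts for this result.

Going by these compounds, it remains open whether other groups on the sulfonyl sulfur, such as a morpholine ring, a longer alkyl amine or a chain ending in a carboxylic acid, would also stay within the scatter. A single swap also cannot show whether the same step would hold on the differing cores of compound 1 and compound 2.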